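Swapping the Outer Aryl Group: Expected Cytotoxicity of Compound 4

A few compounds are considered here, and "the series" means these few. Any claim that something is new, unique, unknown or untested is made for them only; others in the source may bear on it.

Measured compounds:
- compound 1, `COc1cc(CC(O)c2ccc(-c3ccc(C(F)(F)F)cc3)cc2)c([N+](=O)[O-])cc1OC`: 4100 nM
- compound 2, `COc1cc(CC(O)c2ccc(-c3cccc(C#N)c3)cc2)c([N+](=O)[O-])cc1OC`: 5200 nM
- compound 3, `COc1cc(CC(O)c2ccc(-c3ccccc3C#N)cc2)c([N+](=O)[O-])cc1OC`: 9300 nM

Of the compounds shown here, three with a shared core have been tested in an ADME assay on HeLa Rh cells (Homo sapiens) for cytotoxicity, read by microscopy; on this read-out lower numbers stand for higher toxicity in this test and higher numbers for lower toxicity in this test. Compound 1 gives the lowest of the three numbers. Its nearest neighbour is compound 2, and a 1.3-fold higher number from compound 1 to compound 2 (0.10 log units; within the scatter), so these two cannot be told apart. Compound 3 sits furthest away: a 2.3-fold higher number from compound 1 to compound 3 (0.36 log units; beyond the scatter), a modest shift toward lower toxicity. Between compound 2 and compound 3, a 1.8-fold higher number from compound 2 to compound 3 (0.25 log units; within the scatter).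

Compound 4, `COc1cc(CC(O)c2ccc(-c3ccccc3[N+](=O)[O-])cc2)c([N+](=O)[O-])cc1OC`, differs from compound 1 in one place.

2-nitrophenyl in place of 4-(trifluoromethyl)phenyl on an aromatic carbon

Among the measured compounds shown here, the step that bears most directly on this change is the one from compound 1 to compound 3, where another group in the 2-position of the outer phenyl ring replaced the 4-(trifluoromethyl)phenyl and gave a modest rise. The other two steps are within the scatter and give no direction. A 2-nitrophenyl is a different group from a 2-cyanophenyl, so the transfer is uncertain, but a modest rise in the number is the most reasonable expectation: a 1.8-fold higher number from compound 1 to compound 4 (0.26 log units; within the scatter). Compound 4 is therefore estimated at 7500 nM, with a range from 3500 nM to 16000 nM.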

Compound 4, half-maximal cytotoxic concentration: 9500 nM
For compound 4 the middle estimate is 1.3-fold (0.10 log units) below the measured one; the measured number falls inside the stated range.
By their numbers in this assay, from the lowest: compounds 1, 2, 3 and 4 (each within the scatter of the next, the first and the last beyond it).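

In this assay the 2-nitrophenyl group also gives a 2.3-fold higher number from compound 1 to compound 4 (0.36 log units; beyond the scatter), so a second group besides the 2-cyanophenyl of compound 3 now stands beyond the scatter from compound 1, in the direction of lower toxicity. Putting nitro in place of cyano gives a 1.0-fold higher number from compound 3 to compound 4 (0.01 log units; within the scatter) and leaves the two compounds indistinguishable, which means that on this aromatic carbon these two quite different groups cannot be told apart in this test. The 3-cyanophenyl compound keeps the picture from being a clean split, since a 1.8-fold higher number from compound 2 to compound 4 (0.26 log units; within the scatter) is also within the scatter, and compound 2 therefore cannot be separated from compound 1 or from compound 4.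

On these data alone, two groups on the outer ring are too few to show how far this result extends, and it remains open whether an amine, a carboxylic acid or a methoxy group in place of the nitro would also stay level with compound 4 or would move the number in either direction. Nothing shown here offers an explanation for these differences, so the reason behind them remains unknown.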